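The source may report more compounds than this note shows. Statements on the series, on what has been measured and on what is new or still open speak of the compounds shown alone.

Measured compounds:
compound 1, `C[C@@H](NS(C)(=O)=O)c1cncc(N2C(=O)c3ccc(Cl)cc3C2(C)C)c1`: 8 nM
compound 2, `CC(=O)N1CC2(C1)CN(c1cncc(N3C(=O)c4ccc(Cl)cc4C3(C)C)c1)C2`: 23 nM

Both compounds were tested in an assay on cells for inhibition of cytochrome P450 11B2, mitochondrial (Homo sapiens), read by HTRF; on this read-out lower numbers stand for stronger inhibition and higher numbers for weaker inhibition. Compound 1 gives 8 nM, while compound 2 gives 23 nM, the higher of the two numbers, so compound 2 is the weaker inhibitor of the pair and the gap between them lies beyond the usual scatter.

Compound 3, `Cc1ccncc1C(=O)N1CC2(C1)CN(c1cncc(N3C(=O)c4ccc(Cl)cc4C3(C)C)c1)C2`, has not been measured. It differs from compound 2 at a single place: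

4-methylpyridin-3-yl in place of methyl on a carbonyl carbon

Among the measured compounds shown here, the two measured compounds differ from each other elsewhere in the molecule, so no measured pair shows what this particular exchange does. The expectation therefore rests on compound 2 alone. The step of a 1.1-fold higher number from compound 2 to compound 3 (0.04 log units; within the scatter) is expected to be small, within the usual scatter, with no firm direction. Compound 3 is estimated to reach 25 nM, with a likely range from 8 nM to 75 nM.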

Compound 3, half-maximal inhibitory concentration: 14 nM
Compound 3: the middle estimate sits 1.8-fold (0.25 log units) above what was measured; low and high end bracket the measured number.
By their numbers in this assay, from the lowest: compounds 1, 3 and 2 (each within the scatter of the next, the first and the last beyond it).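

In this assay, the carbonyl carbon on the amide-type nitrogen in a ring accepts far more than a methyl: replacing it with 4-methylpyridin-3-yl gives a 1.6-fold lower number from compound 2 to compound 3 (0.22 log units; within the scatter). The entering group brings 7 heavy atoms in place of 1, plus a six-membered aromatic ring and a hydrogen-bond acceptor, yet the two compounds cannot be told apart on this read-out. No supporting measurement bears on why a group of this size leaves the number within the scatter.

Still open, from the compounds shown here alone, is whether the ring nitrogen or the ring methyl matters, which a plain phenyl or an unsubstituted pyridin-3-yl on the same carbonyl carbon would test. It is also unknown how far this tolerance extends, for instance to a ring carrying an amine or a carboxylic acid.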